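Furan in place of bromothiophene: an expected fall in binding

This account rests on a few compounds, and the source may have more. Where it says the series, first, only, none or still open, it means among the compounds named here.

Compound 1, `COc1ccccc1C1=NCC2(CN3CCC2CC3)NC(=O)C1`: 7%
Compound 2, `O=C1CC(c2ccc(Br)s2)=NCC2(CN3CCC2CC3)N1`: 62%

Of the compounds shown here, two sharing one core have been tested in an assay on cell membranes for displacement of a labelled ligand from Neuronal acetylcholine receptor; alpha4/beta2 (Rattus norvegicus), read by scintillation counting, with a stated time of 2 h, tested at 5 uM; a higher number here means more inhibition at the concentration tested (going by the name of the read-out), a lower number less inhibition. Compound 2 gives 62%, the higher of the two numbers; compound 1 gives 7%, a gap well beyond the usual scatter. Compound 3, `O=C1CC(c2ccco2)=NCC2(CN3CCC2CC3)N1`, differs from compound 2 in one place: furan-2-yl in place of 5-bromothiophen-2-yl on a carbon with a double bond to nitrogen. Going by the values given here, no measured pair shows a change of this kind, so the expectation rests on compound 2 alone. In this assay a downward step of a number 27 percentage points lower from compound 2 to compound 3 (beyond the scatter) is expected, larger than the scatter. Compound 3 is therefore estimated at 35%, with a likely range from 10% to 62%.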

Compound 3, a percentage reported as inhibition, at one concentration (the size of the read-out at that concentration, not a potency): 14%
Compound 3: the middle estimate sits 21 percentage points above what was measured, within the range that was stated.
By their numbers in this assay, from the lowest: compounds 1 and 3 (each within the scatter of the next); then compound 2.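

In this assay, the group on the carbon with a double bond to nitrogen proves to matter: furan-2-yl in place of 5-bromothiophen-2-yl gives a number 48 percentage points lower from compound 2 to compound 3 (beyond the scatter) at this position. One five-membered aromatic ring with one hetero atom replacing another is therefore not a neutral swap here, even though the counted hydrogen-bond donors and acceptors stay the same. Nothing measured here gives a reason for the step.

From the compounds shown here alone, the change removes sulfur and bromine together, so the share of each remains open. A plain thiophen-2-yl, carrying no bromine, would separate the two.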